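Changing One Nitrogen Substituent on a Shared Core

This account rests on a few compounds, and the source may have more. Where it says the series, first, only, none or still open, it means among the compounds named here.

In a functional assay on DU-145 cells (Homo sapiens) for cytotoxicity, read by trypan blue exclusion, with a stated time of 96 h (a higher number here means a weaker inhibitor, a lower number a stronger inhibitor), compound 1 (`COC(=O)C(F)(F)Nc1cc(CS(=O)(=O)/C=C/c2c(OC)cc(OC)cc2OC)ccc1OC`) gives 250 nM and compound 2 (`COC(=O)C(Nc1cc(CS(=O)(=O)/C=C/c2c(OC)cc(OC)cc2OC)ccc1OC)c1ccc(Br)cc1`) gives 300 nM. Compound 2 therefore stands within the scatter of compound 1, and the two cannot be ranked. For the measured compounds named here, only one measured step bears on the next change: a 1.2-fold higher number from compound 1 to compound 2 (0.08 log units; within the scatter) on exchanging difluoro(methoxycarbonyl)methyl for (4-bromophenyl)(methoxycarbonyl)methyl on the nitrogen. Compound 3 (`COc1cc(OC)c(/C=C/S(=O)(=O)Cc2ccc(OC)c(NCCC(=O)O)c2)c(OC)c1`) is altered at that same nitrogen, with 2-carboxyethyl in place of (4-bromophenyl)(methoxycarbonyl)methyl on a nitrogen on an aromatic ring. Going by the values given here, that single small step is a thin guide, since no measured compound carries 2-carboxyethyl. In this assay the expected change is a 1.2-fold lower number from compound 2 to compound 3 (0.08 log units; within the scatter) and thus none beyond the scatter, though with wide uncertainty. For compound 3 the estimated value is 250 nM with an expected range from 70 nM to 900 nM as the best present guess.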

Compound 3, half-maximal inhibitory concentration: 5000 nM
The estimate for compound 3 lay 20-fold (1.30 log units) below the measured number, and the stated range ends below it.
By their numbers in this assay, from the lowest: compounds 1 and 2 (each within the scatter of the next); then compound 3.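

Within this assay, this nitrogen is not indifferent to what it carries: placing 2-carboxyethyl there gives a 17-fold higher number from compound 2 to compound 3 (1.22 log units; beyond the scatter), and the comparison with the difluoro group gives a 20-fold higher number from compound 1 to compound 3 (1.30 log units; beyond the scatter). The room for change suggested by the first two compounds therefore does not extend to every group at this position, even though (4-bromophenyl)(methoxycarbonyl)methyl and difluoro(methoxycarbonyl)methyl could not be told apart. Nothing measured here accounts for this loss of activity.

The exchange from compound 2 to compound 3 removes an aromatic ring, shortens the group from 12 heavy atoms to 5 and adds a hydrogen-bond donor, all in one step, so these changes cannot be separated. A 2-(methoxycarbonyl)ethyl group or a plain propyl chain on the same nitrogen would show whether the free carboxylic acid itself matters.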